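Dichloroacetanilides: estimating the para-bromo analogue

The compounds below may be only part of what the source reports. "The series", "measured", "known", "first", "only" and "open" are said of these compounds alone.

Measured so far:
compound 1 `O=C(Nc1ccccc1)C(Cl)Cl` — 130000 nM
compound 2 `O=C(Nc1cccc(Cl)c1)C(Cl)Cl` — 14800 nM
compound 3 `O=C(Nc1cccc(C(F)(F)F)c1)C(Cl)Cl` — 12200 nM

In a functional assay on A549 cells (Homo sapiens) for antiproliferative activity, read by MTT assay, with a stated time of 72 h (on this read-out higher numbers stand for weaker inhibition and lower numbers for stronger inhibition), compound 1 gives the highest number of the three, with compound 2 nearest and compound 3 furthest. Compound 4 `O=C(Nc1ccc(Br)cc1)C(Cl)Cl` differs from compound 1 by bromo in place of hydrogen on an aromatic carbon. Two steps from compound 1 bear on this change, both halogen-like substitutions on the ring: an 8.8-fold lower number from compound 1 to compound 2 (0.94 log units; beyond the scatter) and an 11-fold lower number from compound 1 to compound 3 (1.03 log units; beyond the scatter). Among the measured compounds shown here, a substitution on an aromatic carbon of the shared core has so far lowered the number in this assay, though no step measures a group para to the amide. A step of similar direction, a 6.5-fold lower number from compound 1 to compound 4 (0.81 log units; beyond the scatter), is therefore expected. Compound 4 is estimated at 20000 nM, with a range of 8000 nM to 60000 nM.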

Compound 4, half-maximal inhibitory concentration: 13700 nM
The estimate for compound 4 lay 1.5-fold (0.16 log units) above the measured number; measured number inside the range.
By their numbers in this assay, from the lowest: compounds 3, 4 and 2 (each within the scatter of the next); then compound 1.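

Bromo on an aromatic carbon, para to a group of 6 heavy atoms, gives a 9.5-fold lower number from compound 1 to compound 4 (0.98 log units; beyond the scatter) and extends the lowering seen so far with chloro and trifluoromethyl to this position. By their numbers, compounds 3, 4 and 2 stand each within the scatter of the next, so this position gives no separation among them. No measurement on hand accounts for the step. Still open, from the compounds shown here alone, is whether chloro or trifluoromethyl at this same position would match bromo. Going by these compounds, a hydroxyl, an amine or a carboxylic acid there also remains untested in these compounds.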